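Notes on a chain-extended analogue of compound 3

The source may hold more compounds than are shown below. What is called first, only, known or untested is meant among the compounds shown, and "the series" means these compounds.

Measured so far:
Compound 1 `CC/N=C(/NC#N)NCCCCCn1nc(-c2ccccc2)ccc1=O` in a functional assay on the whole organism (stomach) with Rattus norvegicus as the target; a higher number here means that more compound is needed for the effect, a lower number that less compound is needed: 100 mg/kg
Compound 2 `CC/N=C(/NC#N)NCCCCn1nc(-c2ccccc2)ccc1=O` in this assay: 92 mg/kg
Compound 3 `C/N=C(\S)NCCCn1nc(-c2ccccc2)ccc1=O` in this assay: > 100 mg/kg

Compound 1 and compound 2 sit close together on these numbers. Compound 3 stands at the limit of > 100 mg/kg in this assay, at which 1 of the 3 values shown sits; this is a limit of the assay, not a number, so its place relative to compound 1 and compound 2 is open.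

Compound 4 `C/N=C(\S)NCCCCCn1nc(-c2ccccc2)ccc1=O` differs from compound 3 by a group of 7 heavy atoms (4 carbon, 2 nitrogen, 1 sulfur; no ring) in place of a group of 5 heavy atoms (2 carbon, 2 nitrogen, 1 sulfur; no ring), on a saturated chain carbon, three bonds along the chain from an aromatic nitrogen. Within the data shown here, no measured step covers such a change here. Against the limit for compound 3 the step that the limit leaves unreadable from compound 3 to compound 4 is expected to be none beyond the scatter. Compound 4 is therefore expected to give about 120 mg/kg, between 50 mg/kg and 300 mg/kg, quite possibly again only a limit in this assay.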

Compound 4, dose for half-maximal effect: 35.3 mg/kg
Beside the measured number, compound 4's estimate is 3.4-fold (0.53 log units) above it, and the stated range ends above it.
By their numbers in this assay, from the lowest: compound 4; then compounds 2 and 1 (each within the scatter of the next).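

In this assay, a group of 7 heavy atoms in place of a group of 5 heavy atoms, on a saturated chain carbon, gives an at least 2.8-fold lower number from compound 3 to compound 4 (0.45 log units; beyond the scatter), so this place responds to the change. Compound 4 also stands apart from the two earlier compounds, with a 2.6-fold lower number from compound 2 to compound 4 (0.42 log units; beyond the scatter) and a 2.8-fold lower number from compound 1 to compound 4 (0.45 log units; beyond the scatter). The entry for compound 3 is a limit of the assay, not a number: the limit of > 100 mg/kg in this assay, at which 1 of the 4 values shown sits.

The compounds shown give no cause for these steps. Going by these compounds, whether a longer chain, or an amine in place of the sulfur, keeps the lower number remains open.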